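This account rests on a few compounds, and the source may have more. Where it says the series, first, only, none or still open, it means among the compounds named here.

Compound 3 `COc1ccc2[nH]c(S(=O)(=O)Cc3ccc(OCc4nccc(OC)c4OC)c(OC)c3)nc2c1` gives 898 nM in a functional assay on cells (Erythrocyte, Homo sapiens) (a lower number here means a stronger inhibitor, a higher number a weaker inhibitor), the smallest of the three numbers measured, though its gap to compound 2 `COc1cc(CS(=O)(=O)c2nc3cc(OC(F)F)ccc3[nH]2)ccc1OCc1ncc(C)c(OC)c1C`, which gives 1420 nM, is within the scatter, while its gap to compound 1 `COc1cc(CS(=O)(=O)c2nc3ccccc3[nH]2)ccc1OCc1ncc(C)c(OC)c1C`, which gives 1820 nM, is beyond it. Compound 4 `COc1ccc2[nH]c(S(=O)(=O)Cc3ccc(OCc4ncc(C)c(OC)c4C)c(OC)c3)nc2c1` has not been measured. It differs from compound 3 in one place: 4-methoxy-3,5-dimethylpyridin-2-yl in place of 3,4-dimethoxypyridin-2-yl on a saturated chain carbon bound to an oxygen on an aromatic ring. For the measured compounds named here, no measured step touches this group. Going by the values given here, the only measured step, a 1.3-fold lower number from compound 1 to compound 2 (0.11 log units; within the scatter), changes a substituent on an aromatic carbon of the shared core and so does not bear on this exchange. Compounds 1 and 2 do carry the 4-methoxy-3,5-dimethylpyridin-2-yl group that enters here and both give higher numbers than compound 3, but each also differs from it on the core, so no clean comparison exists. Compound 4 is therefore expected to show a step of a 1.3-fold higher number from compound 3 to compound 4 (0.13 log units; within the scatter), not clearly beyond the scatter. Compound 4 is estimated at 1200 nM, with a range from 500 nM to 2800 nM.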

Compound 4, half-maximal inhibitory concentration: 1210 nM
Compound 4: middle estimate off by 1.0-fold (0.00 log units), on the low side, within the range that was stated.
By their numbers in this assay, from the lowest: compounds 3, 4, 2 and 1 (each within the scatter of the next, the first and the last beyond it).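

In this assay, for the compounds shown here, the exchange of 3,4-dimethoxypyridin-2-yl for 4-methoxy-3,5-dimethylpyridin-2-yl on a saturated chain carbon bound to an oxygen on an aromatic ring (a 1.3-fold higher number from compound 3 to compound 4 (0.13 log units; within the scatter)) is the first measured step at this position, and it stays within the scatter. Compound 4 also gives two further steps on the shared core: methyl in place of difluoromethyl on an oxygen on an aromatic ring (a 1.2-fold lower number from compound 2 to compound 4 (0.07 log units; within the scatter)) and methoxy in place of hydrogen on an aromatic carbon (a 1.5-fold lower number from compound 1 to compound 4 (0.18 log units; within the scatter)). Neither of these lies beyond the scatter, so no single change shown here clearly moves the number.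

Here the pyridin-2-yl group carries only methoxy and methyl substituents, so the effect of an amine or a carboxylic acid on it remains open. No measured evidence bears on these steps.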